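The compounds below may be only part of what the source reports. "The series", "measured", "known", "first", "only" and "open" are said of these compounds alone.

Working notes on the series. In an assay on isolated protein for inhibition of Norepinephrine transporter (Rattus norvegicus), read by radioligand binding (on this read-out higher numbers stand for weaker inhibition and lower numbers for stronger inhibition), compound 1 `COC(=O)C[S+]([O-])CC1CN(C)CCC1c1ccc(Cl)cc1` gives 53 nM, and compound 2 `CN1CCC(c2ccc(Cl)cc2)C(C[S+]([O-])CC(=O)NO)C1` gives 12 nM. Within the data shown here, the single measured step is a 4.4-fold lower number from compound 1 to compound 2 (0.65 log units; beyond the scatter). Among the measured compounds shown here, on the two numbers so far compound 2 stands lowest, with compound 1 the nearest at a gap that is beyond the scatter. Compound 3 `CN1CCC(c2ccc(Cl)cc2)C(C[S+]([O-])CC(=O)N(C)C)C1` is not yet measured; it differs from compound 2 by dimethylamino in place of hydroxyamino on a carbonyl carbon. For the measured compounds named here, the only step that bears on this change is the one from compound 1 to compound 2, in which hydroxyamino entered in place of methoxy and the number fell modestly; in compound 3 the hydroxyamino leaves again, so that gain may be given back, though the incoming dimethylamino is not the methoxy of compound 1. In this assay compound 3 is therefore expected to run higher than compound 2, by about a 3.3-fold higher number from compound 2 to compound 3 (0.52 log units; beyond the scatter). For compound 3 the estimate is 40 nM, with a range from 14 nM to 120 nM.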

Compound 3, inhibition constant: 1250 nM
Estimate against measurement, compound 3: 31-fold (1.49 log units) below, outside the stated range (above it).
By their numbers in this assay, from the lowest: compound 2; then compound 1; then compound 3.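

Among these compounds, on the carbonyl carbon, the group carried matters far more than the single earlier step showed: in this assay there is a 100-fold higher number from compound 2 to compound 3 (2.02 log units; beyond the scatter), much larger than a 4.4-fold lower number from compound 1 to compound 2 (0.65 log units; beyond the scatter). The hydroxyamino gain is not merely given back, since there is also a 24-fold higher number from compound 1 to compound 3 (1.37 log units; beyond the scatter), which places dimethylamino behind both methoxy and hydroxyamino at this position. No measurement at hand accounts for the size of this loss.

The compounds shown leave open which feature of the change carries the loss, as hydroxyamino and dimethylamino differ both in the hydroxyl and in the two methyl groups. Amino or methylamino on the same carbonyl carbon would separate these, and a carboxylic acid there would extend the comparison with methoxy.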